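Pyridyl-to-phenyl swap on the compound 1 core

The source may hold more compounds than are shown below. What is called first, only, known or untested is meant among the compounds shown, and "the series" means these compounds.

Measured in a functional assay on DU-145 cells (Homo sapiens) for cytotoxicity, read by CCK-8 assay and cell counting, with a stated time of 2 days; a higher number here means a weaker inhibitor, a lower number a stronger inhibitor:
compound 1 `Oc1ccc(-c2cc(-c3cccc(Cl)c3)nc(-c3ccccn3)c2)cc1`: 35200 nM
compound 2 `Oc1cccc(-c2cc(-c3cccc(Cl)c3)nc(-c3ccccn3)c2)c1`: "not determined" (no result reported)
compound 3 `Oc1ccc(-c2cc(-c3ccc(Cl)cc3)nc(-c3ccccn3)c2)cc1`: 22500 nM

For the measured compounds named here, compound 1 holds the larger of the two numbers, and the single measured step, a 1.6-fold lower number from compound 1 to compound 3 (0.19 log units; within the scatter), is within the scatter; compound 2 contributes no number. Compound 4 `Oc1ccc(-c2cc(-c3ccccc3)nc(-c3cccc(Cl)c3)c2)cc1` differs from compound 1 by phenyl in place of pyridin-2-yl on an aromatic carbon. Going by the values given here, no measured step touches this position: the one step available concerns only the chlorophenyl group and is itself within the scatter, so nothing supports a shift in either direction. For compound 4 the expected step is a 1.0-fold lower number from compound 1 to compound 4 (0.00 log units; within the scatter), a change not beyond the scatter. Compound 4 is therefore estimated at 35000 nM in this assay, with a range of 10000 nM to 120000 nM.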

Compound 4, half-maximal inhibitory concentration: 5360 nM
The estimate for compound 4 lay 6.5-fold (0.81 log units) above the measured number; the measured number lies below the stated range.
By their numbers in this assay, from the lowest: compound 4; then compounds 3 and 1 (each within the scatter of the next).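

In this assay, this position is the one place in the series where a change gives a step beyond the scatter: a 6.6-fold lower number from compound 1 to compound 4 (0.82 log units; beyond the scatter), with phenyl in place of pyridin-2-yl. The chlorophenyl change, a 1.6-fold lower number from compound 1 to compound 3 (0.19 log units; within the scatter), stayed within the scatter, so the ring bearing the nitrogen matters more here than the placement of the chlorine. Nothing measured accounts for this step.

Still open, on these data alone, is whether phenyl gives a similar step alongside the 4-chlorophenyl group of compound 3. Also open, as far as these compounds go, is whether an amine or a carboxylic acid on the entering phenyl keeps the lower number.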